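The compounds below may be only part of what the source reports. "The series", "measured", "known", "first", "only" and "open" are said of these compounds alone.

Values measured in an ADME assay on HEK293 cells (Homo sapiens) for cytotoxicity, with a stated time of 72 h; on this read-out higher numbers stand for an effect only at larger amounts of compound and lower numbers for an effect already at smaller amounts:

- Compound 1 `O=C(Nc1nc2ccc(Cl)cc2s1)c1cc([N+](=O)[O-])ccc1Cl`: > 27000 nM
- Compound 2 `O=C(Nc1cccc(-c2nc3ccccc3s2)c1)c1cc([N+](=O)[O-])c(O)cc1Cl`: > 25000 nM
- Compound 3 `O=C(Nc1ccc(-c2nc3ccccc3s2)cc1)c1cc([N+](=O)[O-])ccc1Cl`: > 27000 nM

None of these three entries is a number. Compound 1 gives > 27000 nM, which is a limit of this assay. Compound 2 gives > 25000 nM, which is also a limit. Compound 3 gives > 27000 nM, again a limit. Compound 1 therefore stands with the other two compounds as a limit, and the three cannot be placed in any order.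

The next compound, compound 4 `O=C(Nc1nc2ccc(F)cc2s1)c1cc([N+](=O)[O-])ccc1Cl`, has not yet been measured. It keeps the core of compound 1 and carries fluoro in place of chloro on an aromatic carbon. The exchange sits on a six-membered aromatic ring of carbon only, part of a fused or bridged system of two rings.

Among the compounds with values here, no measured pair in this small set differs in only one place, so the data offer no direct guide to the size of such a step. In this assay, no step beyond the scatter is expected, and compound 4 may well be reported only as a limit too. The estimated change is a step that the limit leaves unreadable from compound 1 to compound 4. For compound 4 the estimated value is 30000 nM, with an expected range from 15000 nM to 50000 nM.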

Compound 4, half-maximal effective concentration: > 27000 nM
Compound 4: a limit, no number; the forecaster's own chance of this, stated with the estimate: 80%; the middle value lies beyond the limit too.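

In this assay compound 4 gives > 27000 nM, which is a limit and not a number. No step can be read between compound 1 and compound 4, since both entries are limits. The compounds shown leave open at what concentration, if any, each would reach its half-maximal effect in this assay.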